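A hydroxy group moved, and an open question

The source may hold more compounds than are shown below. What is called first, only, known or untested is meant among the compounds shown, and "the series" means these compounds.

Of the compounds shown here, three sharing one core have been tested in a functional assay on HT-29 cells (Homo sapiens) for inhibition, read by MTT assay, with a stated time of 48 h; a lower number here means a stronger inhibitor, a higher number a weaker inhibitor. Compound 1 `COc1cc(-c2cc(-c3ccc(Br)cc3)nc(-c3ccccc3)n2)cc(OC)c1OC`, which carries a 4-bromophenyl group, gives 3170 nM. Compound 2 `COc1cc(-c2cc(-c3cccc([N+](=O)[O-])c3)nc(-c3ccccc3)n2)cc(OC)c1OC`, with 3-nitrophenyl in that place, is reported only as a limit, > 25000 nM. Compound 3 `COc1cc(-c2cc(-c3cccc(O)c3)nc(-c3ccccc3)n2)cc(OC)c1OC`, with 3-hydroxyphenyl there, is also reported only as a limit, > 25000 nM. It therefore has no true number, and a step that the two limits leave unreadable from compound 2 to compound 3 tells us nothing about size.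

Compound 4 `COc1cc(-c2cc(-c3ccc(O)cc3)nc(-c3ccccc3)n2)cc(OC)c1OC` has not yet been measured. It has the same atoms as compound 3, joined differently, with 4-hydroxyphenyl in place of 3-hydroxyphenyl on an aromatic carbon.

Among the measured compounds shown here, two measured steps bear on this change: an at least 7.8-fold higher number from compound 1 to compound 3 (0.89 log units; beyond the scatter) and an at least 7.8-fold higher number from compound 1 to compound 2 (0.89 log units; beyond the scatter). Each replaces 4-bromophenyl with a different group, so neither isolates where the substituent sits. For the measured compounds named here, still, the only real number among the three belongs to the 4-bromophenyl compound, compound 1, at 3170 nM. A modest move towards a lower number is therefore expected, though compound 4 could also stay at the limit. The expected change is an at least 2.0-fold lower number from compound 3 to compound 4 (0.31 log units; beyond the scatter). For compound 4 the estimate is 12000 nM, with an expected range from 3000 nM to 30000 nM.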

Compound 4, half-maximal inhibitory concentration: 11300 nM
Compound 4: middle estimate off by 1.1-fold (0.03 log units), on the high side; low and high end bracket the measured number.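

Moving the hydroxy group alone changes the result in this assay: 4-hydroxyphenyl in place of 3-hydroxyphenyl gives an at least 2.2-fold lower number from compound 3 to compound 4 (0.34 log units; beyond the scatter), the first step here that alters where a group sits and leaves the atoms the same. The 4-hydroxyphenyl group also separates from the nitro compound, with an at least 2.2-fold lower number from compound 2 to compound 4 (0.34 log units; beyond the scatter), although that step changes both the group and its place, so it cannot isolate either one. Among the compounds shown here, the group itself matters too: with 4-bromophenyl and 4-hydroxyphenyl compared directly, hydroxy in place of bromo gives a 3.6-fold higher number from compound 1 to compound 4 (0.55 log units; beyond the scatter), the first comparison in this set with a true number at both ends.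

The two steps that start from a limit fix only the smallest possible size, and the real gaps could be larger: the limit of > 25000 nM in this assay, at which 2 of the 4 values shown sit. The compounds shown also leave open whether this preference for 4-hydroxyphenyl extends to other groups, such as an amine or a carboxylic acid in place of the hydroxy, and whether any of them could match or pass the bromo compound.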